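Swapping fluoro for methyl on the fused ring

The source may report more compounds than this note shows. Statements on the series, on what has been measured and on what is new or still open speak of the compounds shown alone.

Of the compounds shown here, three sharing one core have been measured in an assay on isolated protein for displacement of a labelled ligand from metabotropic glutamate receptor 5 (Homo sapiens), with a stated time of 60 min, tested at 1 uM; a higher number here means more inhibition at the concentration tested (going by the name of the read-out), a lower number less inhibition. Compound 1, `Cc1cc(C)cc(S(=O)(=O)c2cnc3ccc(C)cc3c2N2CCC(C)CC2)c1`, gives 80%. Compound 2, `Cc1ccc2ncc(S(=O)(=O)c3cccc(Cl)c3)c(N3CCC(C)CC3)c2c1`, gives 91%. Compound 3, `CC1CCN(c2c(S(=O)(=O)c3ccc(C#N)cc3)cnc3ccc(F)cc23)CC1`, gives 75%. Compound 3 stands lowest of the three: its nearest neighbour is compound 1, within the scatter, while compound 2 lies beyond the scatter above it.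

Within the data shown here, the one measured step, a number 11 percentage points higher from compound 1 to compound 2 (beyond the scatter), concerns the aryl group on the sulfonyl sulfur and is modest. Compound 4, `Cc1ccc2ncc(S(=O)(=O)c3ccc(C#N)cc3)c(N3CCC(C)CC3)c2c1`, keeps the nitrile-bearing aryl of compound 3 and changes only the fused ring: methyl in place of fluoro on an aromatic carbon. Among the measured compounds shown here, no measured pair isolates this exchange, so the step from compound 1 to compound 2 does not bear on it directly, and nothing in the data shows the fused-ring substituent moving the read-out on its own.

With no guide, the expected step is small, a number 4 percentage points higher from compound 3 to compound 4 (within the scatter), within the scatter. Compound 4 is therefore estimated at 79% in this assay, with a range from 65% to 92%.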

Compound 4, a percentage reported as inhibition, at one concentration (the size of the read-out at that concentration, not a potency): 55%
Compound 4: the middle estimate sits 24 percentage points above what was measured; measured number below the stated range.
By their numbers in this assay, from the lowest: compound 4; then compounds 3 and 1 (each within the scatter of the next); then compound 2.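

The step of a number 20 percentage points lower from compound 3 to compound 4 (beyond the scatter) shows that this position on the fused ring is not a silent one in this assay: fluoro and methyl each count one heavy atom and neither adds a hydrogen-bond donor or acceptor, yet exchanging them moves the read-out beyond the scatter when 4-cyanophenyl sits on the sulfonyl sulfur. Among these compounds, with methyl held fixed on the fused ring, the aryl group on the sulfur also matters, over a wider span than the earlier compounds showed: 4-cyanophenyl in place of 3-chlorophenyl gives a number 36 percentage points lower from compound 2 to compound 4 (beyond the scatter), and 4-cyanophenyl in place of 3,5-dimethylphenyl gives a number 25 percentage points lower from compound 1 to compound 4 (beyond the scatter). Nothing available explains either the loss on the fused ring or the loss on the sulfonyl side.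

Among the compounds shown here, the fluoro and methyl pair is seen only with 4-cyanophenyl on the sulfur, so whether the exchange would have the same size with 3-chlorophenyl or 3,5-dimethylphenyl remains open. Also open, on these data alone, is how a bare hydrogen, a chloro group or a methoxy group at this position would compare with fluoro and methyl.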